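A Ring Swap at the Benzyl-Type Position, Expected Effect

The source may report more compounds than this note shows. Statements on the series, on what has been measured and on what is new or still open speak of the compounds shown alone.

Three measured compounds share one core and differ at two places. Compound 1 `O=C(COCc1ccccc1)N1CCN(c2ccc(Cl)cc2)CC1` gives 350 nM in a functional assay on HEK293 cells for positive allosteric modulation of metabotropic glutamate receptor 5 (Homo sapiens), read by FLIPR and calcium flux; on this read-out higher numbers stand for an effect only at larger amounts of compound and lower numbers for an effect already at smaller amounts. Compound 2 `O=C(COCc1ccccc1)N1CCN(c2ccc(Cl)cc2Cl)CC1` gives 1000 nM in this assay, and the step of a 2.9-fold higher number from compound 1 to compound 2 (0.46 log units; beyond the scatter) shows that adding the second chloro weakened the effect. Compound 3 `O=C(COCc1cccnc1)N1CCN(c2ccc(Cl)cc2Cl)CC1` gives 1090 nM; the step of a 1.1-fold higher number from compound 2 to compound 3 (0.04 log units; within the scatter) shows that exchanging the phenyl for pyridin-3-yl changed nothing that can be told from the scatter. Compound 3 therefore holds the highest of the three numbers, but its gap to compound 2 lies within the scatter, and only its gap to compound 1 is a real difference.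

Compound 4 `O=C(COCc1ncccn1)N1CCN(c2ccc(Cl)cc2Cl)CC1` has not been measured. It differs from compound 3 in one place: pyrimidin-2-yl in place of pyridin-3-yl on a saturated chain carbon bound to an oxygen on a saturated carbon. Among the measured compounds shown here, the only measured step at this position is a 1.1-fold higher number from compound 2 to compound 3 (0.04 log units; within the scatter), which was within the scatter, so a further change of the same aromatic ring at the same place gives no reason to expect a large move. The step of a 2.9-fold higher number from compound 1 to compound 2 (0.46 log units; beyond the scatter) concerns a different part of the molecule and does not bear on this change. Compound 4 is thus expected to give about 1400 nM, with a range from 500 nM to 4000 nM, which means an expected step of a 1.3-fold higher number from compound 3 to compound 4 (0.11 log units; within the scatter) that would stay within the scatter.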

Compound 4, half-maximal effective concentration: 18000 nM
Compound 4: the middle estimate sits 13-fold (1.11 log units) below what was measured; measured number outside the range, above it.
By their numbers in this assay, from the lowest: compound 1; then compounds 2 and 3 (each within the scatter of the next); then compound 4.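

The ring at this position is not freely exchangeable: phenyl and pyridin-3-yl could not be told apart, yet this assay shows a 17-fold higher number from compound 3 to compound 4 (1.22 log units; beyond the scatter) and likewise an 18-fold higher number from compound 2 to compound 4 (1.26 log units; beyond the scatter) once pyrimidin-2-yl enters. The earlier step within the scatter therefore held for one ring swap only, and a change that keeps a six-membered aromatic ring at this saturated chain carbon, with no net charge and no hydrogen-bond donor, can still move the number a long way. Nothing shown gives a measured reason for the size of this step.

Pyrimidin-2-yl differs from pyridin-3-yl both in its count of hetero atoms and in where the ring is attached, so these compounds cannot say which of the two goes with the higher number, and pyridin-2-yl or pyrimidin-5-yl at the same place would pull the two apart. All three ring comparisons also carry the same dichloro-substituted aryl group, which leaves open whether pyrimidin-2-yl would give a step of similar size on the single-chloro aryl group of compound 1.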